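The source may hold more compounds than are shown below. What is called first, only, known or untested is meant among the compounds shown, and "the series" means these compounds.

In a functional assay on HeLa cells (Homo sapiens) for inhibition, read by MTT assay, with a stated time of 72 h (a lower number here means a stronger inhibitor, a higher number a weaker inhibitor), compound 1 (`COc1cc(NC(C)CCCNC(=O)Nc2ccc(F)cc2)c2ncccc2c1`) gives 20000 nM and compound 3 (`COc1cc(NC(C)CCCNC(=O)Nc2cc(C(F)(F)F)cc(C(F)(F)F)c2)c2ncccc2c1`) gives 3100 nM on the shared core. Compound 2 (`COc1cc(NC(C)CCCNC(=O)Nc2cccc(O)c2)c2ncccc2c1`) stands at 48000 nM as the highest of the three numbers, which makes it the weakest inhibitor measured so far.

The change to compound 4 (`COc1cc(NC(C)CCCNC(=O)NNC(=O)Nc2cccc(Cl)c2)c2ncccc2c1`) puts ((3-chlorophenyl)carbamoyl)amino in place of 3-hydroxyphenyl on an amide-type nitrogen. For the measured compounds named here, the counted difference is ((3-chlorophenyl)carbamoyl)amino in place of 3-hydroxyphenyl on an amide-type nitrogen and no measured compound carries the entering group, so the evidence is indirect.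

Going by the values given here, the one measured step at this place is a 2.4-fold higher number from compound 1 to compound 2 (0.38 log units; beyond the scatter) and it is modest. It is a swap between two aryl groups and only a rough guide to the present change. With compound 2 at the top of the measured numbers, a modest move towards a lower number in this assay is expected rather than a further rise. The expected step is a 3.2-fold lower number from compound 2 to compound 4 (0.51 log units; beyond the scatter) with wide uncertainty. The estimated value for compound 4 is 15000 nM and the range 5000 nM to 45000 nM is expected to contain the measurement.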

Compound 4, half-maximal inhibitory concentration: 44000 nM
Estimate against measurement, compound 4: 2.9-fold (0.47 log units) below; measured number inside the range.
By their numbers in this assay, from the lowest: compound 3; then compound 1; then compounds 4 and 2 (each within the scatter of the next).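

In this assay, ((3-chlorophenyl)carbamoyl)amino on the amide-type nitrogen gives a 1.1-fold lower number from compound 2 to compound 4 (0.04 log units; within the scatter), so the larger entering group with its extra carbamoyl unit cannot be told apart from 3-hydroxyphenyl at this place. Set against 4-fluorophenyl, the same group gives a 2.2-fold higher number from compound 1 to compound 4 (0.34 log units; beyond the scatter), which puts compound 4 with compound 2 on the high side of compound 1. Nothing measured on these compounds accounts for this result.

The compounds shown do not separate the chlorine from the added carbamoyl-amino link, and a plain 3-chlorophenyl group at this place would bear on that. Also open, from the compounds shown here alone, is how this nitrogen responds to a group without an aromatic ring, such as an amine or a carboxylic acid on a short chain.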